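A few compounds are considered here, and "the series" means these few. Any claim that something is new, unique, unknown or untested is made for them only; others in the source may bear on it.

Measured compounds:
Compound 1, `C[C@](NC(=O)[C@H](CCCCN)NC(=O)[C@H](CCCNC(=N)N)NC(=O)c1ccccc1)(C(N)=O)c1ccccc1`: 11.8%
Compound 2, `CC(NC(=O)[C@H](CCCCN)NC(=O)[C@H](CCCNC(=N)N)NC(=O)c1ccccc1)(C(N)=O)c1ccccc1`: <= 5%
Compound 3, `C[C@@](NC(=O)[C@H](CCCCN)NC(=O)[C@H](CCCNC(=N)N)NC(=O)c1ccccc1)(C(N)=O)c1ccccc1`: 20.7%

In an assay on isolated protein for inhibition of Trypsin (Homo sapiens), read by fluorescence, with a stated time of 15 min, tested at 50 uM (on this read-out lower numbers stand for less inhibition and higher numbers for more inhibition at the one concentration tested (going by the name of the read-out)), compound 3 gives 20.7%. Of the two numbers reported, this is the highest, but the step of a number 8.9 percentage points higher from compound 1 to compound 3 (within the scatter) lies within the usual scatter, so compound 3 and compound 1 cannot be told apart on these data. The value of compound 2 is a limit of the assay and not a number. The step of a number at least 15.7 percentage points higher from compound 2 to compound 3 (beyond the scatter) is the only one that reaches beyond the scatter, and the step of a number at least 6.8 percentage points lower from compound 1 to compound 2 (that floor lies within the scatter) has a floor within it. All three measured steps concern only a stereocentre at a saturated chain carbon the fact that one of compounds 1 and 2 is drawn with a defined configuration and the other without, at the place where they differ the fact that one of compounds 1 and 3 is drawn with a defined configuration and the other without, at the place where they differ (the fact that one of compounds 2 and 3 is drawn with a defined configuration and the other without, at the place where they differ).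

Compound 4, `N=C(N)NCCC[C@H](NC(=O)c1ccccc1)C(=O)N[C@@H](CCCCN)C(=O)N(CC(N)=O)c1ccccc1`, differs from compound 3 by (carbamoylmethyl)(phenyl)amino in place of (1-carbamoyl-1-phenylethyl)amino on a carbonyl carbon. Among the measured compounds shown here, none of the measured steps touches this part of the structure, so no measured step bears directly on it; the series as a whole sits at low inhibition, with one value at the limit (the limit of <= 5% in this assay, at which 1 of the 3 values shown sits). Compound 4 is therefore expected to stay near the low end, estimated at 10% in this assay, between 0% and 25%. This estimate means an expected step of a number 10.7 percentage points lower from compound 3 to compound 4 (beyond the scatter), which would not go beyond the scatter.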

Compound 4, a percentage reported as inhibition, at one concentration (the size of the read-out at that concentration, not a potency): <= 5%
Compound 4: a limit, no number; the forecaster's own chance of this, stated with the estimate: 35%; at least 5 percentage points between middle value and limit.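

In this assay, among the compounds shown here, the earlier steps concerned only how one stereocentre was drawn, whereas this is the first measured change to the group itself on a carbonyl carbon whose other neighbour is a saturated chain carbon: with (carbamoylmethyl)(phenyl)amino in place of (1-carbamoyl-1-phenylethyl)amino, the read-out shows a number at least 15.7 percentage points lower from compound 3 to compound 4 (beyond the scatter). The same exchange, read from the other defined configuration, gives a number at least 6.8 percentage points lower from compound 1 to compound 4 (that floor lies within the scatter), and the step that pairs two limits cannot be read. Compound 4 gives a limit of the assay and not a number, so only a floor on these steps is known: the limit of <= 5% in this assay, at which 2 of the 4 values shown sit.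

The compounds shown leave open which feature of the exchange carries the step, as the entering and leaving groups differ in more than one feature and no compound here separates them. They also leave open whether a carboxylic acid in place of the carbamoyl, or a longer chain carrying the carbamoyl, would lift the read-out clear of the limit in this assay.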